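The source may hold more compounds than are shown below. What is called first, only, known or untested is meant among the compounds shown, and "the series" means these compounds.

In an ADME assay on HCT-116 cells (Homo sapiens) for cytotoxicity, read by CellTiter-Glo, with a stated time of 72 h (a higher number here means a weaker inhibitor, a lower number a stronger inhibitor), three sulfonamides have been measured and none yields a number. Compound 1 (`Cc1cc(Cl)cc(Cl)c1S(=O)(=O)N1CCC(N2CCC(C)CC2)CC1`) gives > 5000 nM, which is a limit. Compound 2 (`CC1CCN(C2CCN(S(=O)(=O)c3ccc(C#N)cc3)CC2)CC1`) gives > 5000 nM, also a limit. Compound 3 (`CC1CCN(C2CCN(S(=O)(=O)c3cn(C)cn3)CC2)CC1`) gives > 10000 nM, again a limit, and this is all that is known of where it stands. Among the compounds with values here, the only measured step, a step that the two limits leave unreadable from compound 2 to compound 3, offers no size to carry forward.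

Compound 4 (`CC1CCN(C2CCN(S(=O)(=O)c3ccc(Cl)cc3Cl)CC2)CC1`) differs from compound 3 by one change, with 2,4-dichlorophenyl in place of 1-methyl-1H-imidazol-4-yl on a sulfonyl sulfur. The closest measured comparison is compound 1, whose aryl group also carries chlorine and whose > 5000 nM is a limit. With no readable step to draw on, only a modest move towards stronger inhibition is expected, and compound 4 may well stay at a limit. The estimated change is an at least 1.6-fold lower number from compound 3 to compound 4 (0.22 log units; that floor lies within the scatter). For compound 4 the expected value is 6000 nM, with an estimated range of 2000 nM to 15000 nM.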

Compound 4, half-maximal inhibitory concentration: > 5000 nM
Compound 4: only a limit was reported (the forecaster's own chance of this, stated with the estimate: 70%); the middle value does not contradict the limit.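

Compound 4 also gives only a limit, so the steps to it from compound 1, compound 2 and compound 3 cannot be read: the limit of > 5000 nM in this assay, at which 3 of the 4 values shown sit.

The compounds shown leave open whether any group on the sulfonyl sulfur would give a number rather than a limit in this assay.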